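The source may report more compounds than this note shows. Statements on the series, on what has been measured and on what is new or still open speak of the compounds shown alone.

Compound 1 `CCOc1cc(=O)oc2cc(OCc3cccc(F)c3)ccc12` and compound 2 `CCCOc1cc(=O)oc2cc(OCc3cccc(F)c3)ccc12` share one core. In an assay on isolated protein (strain Sprague-Dawley) for inhibition of Amine oxidase [flavin-containing] B (Rattus norvegicus), read by spectrophotometry, with a stated time of 5 min (a higher number here means a weaker inhibitor, a lower number a stronger inhibitor), compound 1 gives 263 nM. Compound 2 gives 407 nM in this assay. The change between them, (methyl in place of hydrogen on a saturated chain carbon, two bonds along the chain from an oxygen on an aromatic ring), makes the step of a 1.5-fold higher number from compound 1 to compound 2 (0.19 log units; within the scatter). Compound 3 `CNc1cc(=O)oc2cc(OCc3cccc(Cl)c3)ccc12` sits on another core; the difference between the two cores is not broken down here. In this assay compound 3 gives 8.71 nM, the lowest of the three numbers, with compound 1 and compound 2 both beyond the scatter above it. Compound 4 `CCNc1cc(=O)oc2cc(OCc3cccc(Cl)c3)ccc12` is not yet measured and differs from compound 3 by methyl in place of hydrogen on a saturated chain carbon bound to a nitrogen on an aromatic ring. This is the same kind of change as that from compound 1 to compound 2, but at a different place: on a saturated chain carbon bound to a nitrogen on an aromatic ring, rather than two bonds along the chain from an oxygen on an aromatic ring. Resting only on a 1.5-fold higher number from compound 1 to compound 2 (0.19 log units; within the scatter), a step of about a 1.4-fold higher number from compound 3 to compound 4 (0.14 log units; within the scatter) is expected in this assay. Compound 4 is therefore estimated at 12 nM, between 5 nM and 30 nM.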

Compound 4, half-maximal inhibitory concentration: 28.2 nM
The estimate for compound 4 lay 2.4-fold (0.37 log units) below the measured number, and the stated range covers the measured number.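

In this assay, methyl in place of hydrogen on a saturated chain carbon bound to a nitrogen on an aromatic ring gives a 3.2-fold higher number from compound 3 to compound 4 (0.51 log units; beyond the scatter). Set beside the earlier step, the same change does not differ in size beyond the scatter between the two cores: the same change on two cores in this assay, a 1.5-fold higher number (0.19 log units; within the scatter) from compound 1 to compound 2 and a 3.2-fold higher number (0.51 log units; beyond the scatter) from compound 3 to compound 4, 2.1-fold (0.32 log units) apart, within the scatter of two such steps. For the compounds shown here, with one pair on each core and the change at a different place on each, this shows only that these two steps agree; it sets no rule for other cores or other places.

From the compounds shown here alone, a longer chain on that nitrogen, such as propyl, and a plain amine there remain open on the core of compound 3. Going by these compounds, the two cores' separate contributions to their difference also remain open.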